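Cytotoxicity Read-out for a Saturated Ring Replacement

The compounds below may be only part of what the source reports. "The series", "measured", "known", "first", "only" and "open" are said of these compounds alone.

Measured compounds:
- compound 1 `CO[C@H]1CC[C@H](NC(=O)c2n[nH]cc2NC(=O)c2cnc3ccccn23)CC1`: 5900 nM
- compound 2 `CO[C@H]1CC[C@H](NC(=O)c2n[nH]cc2NC(=O)c2ncoc2-c2ccccc2)CC1`: 28000 nM
- compound 3 `CO[C@H]1CC[C@H](NC(=O)c2n[nH]cc2NC(=O)c2c(C)nc3ccccn23)CC1`: 34000 nM

In an ADME assay on MRC5 cells (Homo sapiens) for inhibition, with a stated time of 72 h (on this read-out lower numbers stand for an effect already at smaller amounts and higher numbers for an effect only at larger amounts of compound), compound 1 gives 5900 nM, the lowest of the three numbers. Compound 2 gives 28000 nM, and compound 3 gives 34000 nM. For the measured compounds named here, only one single-place step is available: a 5.8-fold higher number from compound 1 to compound 3 (0.76 log units; beyond the scatter), a modest rise beyond the scatter. Compound 2 differs from compound 1 in more than one place, so its higher number can only be noted, not traced to one change.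

Compound 4 `CO[C@H]1CC[C@H](NC(=O)c2n[nH]cc2NC(=O)C2CCC(F)(F)CC2)CC1` has not yet been measured in this assay. Relative to compound 1 the change is a group of 8 heavy atoms (6 carbon, 2 fluorine; one six-membered non-aromatic ring of carbon only) in place of a group of 9 heavy atoms (7 carbon, 2 nitrogen; one five-membered aromatic ring with 2 hetero atoms, one six-membered aromatic ring with 1 hetero atom), on a carbonyl carbon. Going by the values given here, this is a larger replacement than any step measured here; no measured pair exchanges an aromatic group for a saturated ring on that carbonyl carbon. Among the compounds with values here, what the data show is that each departure from compound 1 so far has raised the number, and the one clean step, a 5.8-fold higher number from compound 1 to compound 3 (0.76 log units; beyond the scatter), did so modestly.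

On that basis, compound 4 is expected to give a higher number than compound 1, with the step estimated as a 3.4-fold higher number from compound 1 to compound 4 (0.53 log units; beyond the scatter). The estimate for compound 4 is 20000 nM, with a range from 6000 nM to 60000 nM.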

Compound 4, half-maximal effective concentration: > 50000 nM
Compound 4 was reported as a limit (the forecaster's own chance of this, stated with the estimate: 25%); middle value at least 2.5-fold (0.39 log units) away from the limit.
By their numbers in this assay, from the lowest: compound 1; then compounds 2 and 3 (each within the scatter of the next). At a limit, above all of these: compound 4.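

In this assay, for the compounds shown here, the step of an at least 8.4-fold higher number from compound 1 to compound 4 (0.92 log units; beyond the scatter) is the first measured exchange of an aromatic group for a saturated ring on this carbonyl carbon, with 4,4-difluorocyclohexyl as the entering group. It shows that this place accepts a non-aromatic group without the number falling below that of the fused aromatic group in compound 1, and that a change here can carry the read-out beyond what compound 3 reaches with a single methyl. Compound 4 is reported as a limit and not as a number: the limit of > 50000 nM in this assay, at which 1 of the 4 values shown sits.

Going by these compounds, how far compound 4 really lies past that limit stays open, and so does whether the rise goes with the saturated ring itself or with its two fluorine atoms. A plain cyclohexyl group, or a six-membered saturated ring bearing an amine, on the same carbonyl carbon would be needed to separate these possibilities, and the compounds shown give no cause for the change.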